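Changing the aryl group on the ring amine nitrogen

A few compounds are considered here, and "the series" means these few. Any claim that something is new, unique, unknown or untested is made for them only; others in the source may bear on it.

Compound 3 `CCCc1nc(-c2ccccc2)c(CNCCCN2CCN(c3ccccc3C)CC2)o1` gives 8750 nM in an assay on HEK293 cells for inhibition of Voltage-dependent T-type calcium channel subunit alpha-1G (Homo sapiens), read by patch clamp (on this read-out higher numbers stand for weaker inhibition and lower numbers for stronger inhibition), the second highest of the three numbers measured: compound 2 `CCCc1nc(-c2ccccc2)c(CNCCCN2CCN(c3ccccc3F)CC2)o1` gives 16100 nM, and compound 1 `CCCc1nc(-c2ccccc2)c(CNCCCN2CCN(c3cccc(F)c3)CC2)o1` gives 3030 nM. The step of a 1.8-fold lower number from compound 2 to compound 3 (0.26 log units; within the scatter) lies within the scatter, whereas a 2.9-fold higher number from compound 1 to compound 3 (0.46 log units; beyond the scatter) and a 5.3-fold higher number from compound 1 to compound 2 (0.73 log units; beyond the scatter) lie beyond it. Compound 4 `CCCc1nc(-c2ccccc2)c(CNCCCN2CCN(c3ccc(Cl)cc3)CC2)o1` differs from compound 3 by 4-chlorophenyl in place of 2-methylphenyl on an amine nitrogen in a ring. Among the measured compounds shown here, none of the measured steps brings in a 4-chlorophenyl, so they offer only a loose guide; they do show that the 3-fluorophenyl of compound 1 gave the lowest number of the set. Compound 4 is therefore expected to give roughly 4500 nM in this assay, somewhere between 1200 nM and 16000 nM, which would mean a step of a 1.9-fold lower number from compound 3 to compound 4 (0.29 log units; within the scatter).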

Compound 4, half-maximal inhibitory concentration: 1310 nM
Compound 4: the middle estimate sits 3.4-fold (0.54 log units) above what was measured; measured number inside the range.
By their numbers in this assay, from the lowest: compound 4; then compound 1; then compounds 3 and 2 (each within the scatter of the next).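

Placing 4-chlorophenyl on the ring amine nitrogen gives the lowest number of the set, with a 2.3-fold lower number from compound 1 to compound 4 (0.36 log units; beyond the scatter), a 6.7-fold lower number from compound 3 to compound 4 (0.82 log units; beyond the scatter) and a 12-fold lower number from compound 2 to compound 4 (1.09 log units; beyond the scatter). Among the compounds shown here, the aryl group alone can therefore shift the number further than the earlier compounds showed, and a group at this place can go beyond the 3-fluorophenyl of compound 1. Nothing measured here explains why this aryl group gives the lowest number.

The compounds shown leave open whether the chlorine counts or the place it holds on the phenyl ring, and how a bromine or a methoxy group would compare there.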